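The source may hold more compounds than are shown below. What is called first, only, known or untested is meant among the compounds shown, and "the series" means these compounds.

Measured compounds in a functional assay on the whole organism (strain Kunming) with Mus musculus as the target, with a stated time of 0.5 h, at a dose of 100 mg/kg by the intraperitoneal route; a higher number here means a weaker effect of the compound at the dose given, a lower number a stronger effect:
- compound 1 `COc1cc(OC)c(OC)cc1/C=C/COC(=O)/C=C/c1ccc(Br)cc1`: 100%
- compound 2 `COc1cc(OC)c(OC)cc1/C=C/COC(=O)/C=C/c1cc(OC)c(OC)c(OC)c1`: 100%
- compound 3 `COc1cc(OC)c(OC)cc1/C=C/COC(=O)/C=C/c1ccc(OC)c(OC)c1OC`: 100%

Compound 1 stands level with compounds 2 and 3 at the digits shown; its nearest neighbour on the numbers is compound 2, its furthest compound 3, and in both cases there is no change within the scatter. For the measured compounds named here, no pair among the measured compounds differs in one place only, so no single-point step is available.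

Compound 4 `COc1cc(OC)c(OC)cc1/C=C/COC(=O)/C=C/c1ccccc1Cl` has not been measured in this assay. It differs from compound 1 as follows: 2-chlorophenyl in place of 4-bromophenyl on a double-bonded chain carbon bound to a double-bonded chain carbon.

Given that compounds 1, 2 and 3 all sit at the same reading, no step beyond the scatter is expected; the expected step of no change at the digits printed from compound 1 to compound 4 (within the scatter) is none. For compound 4 the estimate in this assay is 100%, with a range from 85% to 100%.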

Compound 4, a percentage reported as activity, at one dose (the size of the read-out at that dose, not a potency): 100%
Compound 4: the middle estimate sits on the measured number at the digits printed; measured number inside the range.
By their numbers in this assay, from the lowest: compounds 1, 2, 3 and 4 (each within the scatter of the next).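

In this assay, for the compounds shown here, 2-chlorophenyl in place of 4-bromophenyl on a double-bonded chain carbon bound to a double-bonded chain carbon gives no change at the digits printed from compound 1 to compound 4 (within the scatter) as the first single-place step. This one step changes both the halogen and its place on the phenyl ring, and the two changes cannot be separated here. No evidence bears on this result.

As far as these compounds go, whether any change at this position can move the reading remains open, for example an amine or a carboxylic acid on the phenyl ring. Also open, from the compounds shown here alone, is whether an amide in place of the ester would do so.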